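A few compounds are considered here, and "the series" means these few. Any claim that something is new, unique, unknown or untested is made for them only; others in the source may bear on it.

Measured so far:
compound 1 `CNC(=O)[C@@H](c1ccccc1)N1CCn2c(CC3CC3)nc(Cl)c2[C@@H]1CCc1ccc(C(F)(F)F)cc1`: 1430 nM
compound 2 `CCc1nc(C(C)C)c2n1CCN([C@@H](C(=O)NC)c1ccccc1)C2CCc1ccc(C(F)(F)F)cc1`: 10000 nM

In a functional assay on CHO cells for antagonist activity at Orexin/Hypocretin receptor type 1 (Homo sapiens), read by FLIPR and calcium flux (on this read-out lower numbers stand for stronger inhibition and higher numbers for weaker inhibition), compound 2 gives 10000 nM, the highest of the two numbers, while compound 1 gives 1430 nM, a gap beyond the scatter. Compound 3 `CCc1nc(C)c2n1CCN([C@@H](C(=O)NC)c1ccccc1)C2CCc1ccc(C(F)(F)F)cc1` differs from compound 2 by methyl in place of isopropyl on an aromatic carbon. Among the measured compounds shown here, no pair of measured compounds isolates this change, so its size is uncertain. The step of a 2.5-fold lower number from compound 2 to compound 3 (0.40 log units; beyond the scatter) is expected to be modest, toward stronger inhibition. Compound 3 is therefore estimated at 4000 nM, with a range from 1000 nM to 15000 nM.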

Compound 3, half-maximal inhibitory concentration: 10000 nM
For compound 3 the middle estimate is 2.5-fold (0.40 log units) below the measured one, within the range that was stated.
By their numbers in this assay, from the lowest: compound 1; then compounds 2 and 3 (each within the scatter of the next).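

In this assay, among the compounds shown here, methyl in place of isopropyl on this aromatic carbon of the five-membered ring gives no change at the digits printed from compound 2 to compound 3 (within the scatter) and so provides the first pair that isolates a change at this position. Going from the group of 3 heavy atoms to the group of 1 heavy atom does not separate the two compounds on this read-out. Nothing measured here accounts for this result and the compounds shown leave open whether an amine, a hydroxymethyl group or a longer chain on this carbon would separate from isopropyl and methyl.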